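Two Chloroaryl Sulfonyl Quinolines and a Fluorophenyl Analogue

A few compounds are considered here, and "the series" means these few. Any claim that something is new, unique, unknown or untested is made for them only; others in the source may bear on it.

Compound 1 `O=S(=O)(c1ccc(F)c(Cl)c1)c1cnc2c(F)cccc2c1-c1cccc(Cl)c1`: 0.18 mL/min
Compound 2 `O=S(=O)(c1ccc(F)c(Cl)c1)c1cnc2c(F)cccc2c1-c1ccc(Cl)cc1`: 0.01 mL/min

In an ADME assay on microsomes from liver (Homo sapiens) for metabolic stability, tested at 2.5 uM (on this read-out lower numbers stand for slow clearance and higher numbers for fast clearance), compound 2 gives 0.01 mL/min, the lowest of the two numbers measured; its nearest neighbour is compound 1, which in this assay gives 0.18 mL/min. Going by the values given here, the single measured step, an 18-fold lower number from compound 1 to compound 2 (1.26 log units; beyond the scatter), came with 4-chlorophenyl in place of 3-chlorophenyl on an aromatic carbon of the shared core. Compound 3 `O=S(=O)(c1ccc(F)c(Cl)c1)c1cnc2c(F)cccc2c1-c1cccc(F)c1` is not yet measured. It differs from compound 2 by 3-fluorophenyl in place of 4-chlorophenyl on an aromatic carbon. This change is in the reverse sense of the measured step on the same aromatic carbon, though with a different halogen, so an increase beyond the scatter is expected, likely smaller than the step from compound 1 to compound 2. The estimate for compound 3 in this assay is 0.08 mL/min, with a range from 0.02 mL/min to 0.3 mL/min, which is expected to correspond to an 8.0-fold higher number from compound 2 to compound 3 (0.90 log units; beyond the scatter).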

Compound 3, intrinsic clearance in a liver preparation (reported as CLH), per the amount of preparation that the assay uses: 1.23 mL/min
For compound 3 the middle estimate is 15-fold (1.19 log units) below the measured one; the measured number lies above the stated range.
By their numbers in this assay, from the lowest: compound 2; then compound 1; then compound 3.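

In this assay, the number depends not only on where the halogen sits on the phenyl group at this aromatic carbon but also on which halogen it is: with the position held, fluoro in place of chloro gives a 6.8-fold higher number from compound 1 to compound 3 (0.83 log units; beyond the scatter) on this read-out. The change from 4-chlorophenyl to 3-fluorophenyl, which alters both halogen and position, gives a 120-fold higher number from compound 2 to compound 3 (2.09 log units; beyond the scatter) and leaves compound 3 with the highest number of the three. Nothing measured here offers a reason for either step.

The compounds shown leave open how 4-fluorophenyl would read on this carbon, which would show whether the swap of halogen counts for the same at the other position. They also leave open where plain phenyl, or a phenyl carrying a methoxy group or an amine instead of a halogen, would fall.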